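Swapping the pendant ring: from methylphenyl to pyridinyl

A few compounds are considered here, and "the series" means these few. Any claim that something is new, unique, unknown or untested is made for them only; others in the source may bear on it.

Two compounds share one core and differ only in the group attached to it. Compound 1 `CC(Oc1ccccc1-c1ccc([N+](=O)[O-])cc1)C1=NCCN1` carries a nitro group on its outer ring and in an assay on CHO cells for displacement of a labelled ligand from Alpha-2C adrenergic receptor (Homo sapiens) (on this read-out lower numbers stand for stronger inhibition and higher numbers for weaker inhibition), compound 1 gives 302 nM. Compound 2 `Cc1ccc(-c2ccccc2OC(C)C2=NCCN2)cc1` carries a methyl group in the same place and in this assay compound 2 gives 251 nM. For the measured compounds named here, the one measured step, a 1.2-fold lower number from compound 1 to compound 2 (0.08 log units; within the scatter), shows that exchanging those two groups changes little. Compound 2 thus holds the lowest of the two numbers, but its gap to compound 1 lies within the scatter, so neither can be called the stronger binder.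

Compound 3 `CC(Oc1ccccc1-c1cccnc1)C1=NCCN1` goes further: pyridin-3-yl in place of 4-methylphenyl on an aromatic carbon. Going by the values given here, no measured step swaps the whole outer ring, so the step from compound 1 to compound 2 bears on it only loosely, by suggesting the outer ring tolerates small edits without a large shift. A step of modest size, if any, is expected, leaning toward a weaker number once the 4-methylphenyl is gone.

Compound 3 is therefore estimated at 500 nM, within 150 nM to 1600 nM, an expected step of a 2.0-fold higher number from compound 2 to compound 3 (0.30 log units; within the scatter).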

Compound 3, inhibition constant: 64.6 nM
Beside the measured number, compound 3's estimate is 7.7-fold (0.89 log units) above it; measured number below the stated range.
By their numbers in this assay, from the lowest: compound 3; then compounds 2 and 1 (each within the scatter of the next).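

In this assay, exchanging the whole outer ring does more than editing the group on it: pyridin-3-yl in place of 4-methylphenyl gives a 3.9-fold lower number from compound 2 to compound 3 (0.59 log units; beyond the scatter) and so moves the number beyond the scatter, while methyl in place of nitro gave a 1.2-fold lower number from compound 1 to compound 2 (0.08 log units; within the scatter) and stayed within it. This position, on an aromatic carbon ortho to a group of 8 heavy atoms, therefore accepts a ring with a hetero atom, and the number falls instead of rising. The swap alters two things at once, however: the entering ring brings a nitrogen, counted as 1 hydrogen-bond acceptor, and it also lacks the methyl group, so this single step cannot say which alteration goes with the lower number.

An unsubstituted phenyl ring on the same core would separate those two alterations, and a methyl group or an amine on the pyridin-3-yl ring would show whether the new ring tolerates further edits. Nothing at hand explains why the number falls with this ring.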